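A few compounds are considered here, and "the series" means these few. Any claim that something is new, unique, unknown or untested is made for them only; others in the source may bear on it.

Measured so far:

- Compound 1, `O=S(=O)(NCCNCc1cccc2ccccc12)c1cc(C(F)(F)F)cc(C(F)(F)F)c1`: 21000 nM
- Compound 2, `O=S(=O)(NCCCCNCc1ccc(Br)cc1)c1cc(C(F)(F)F)cc(C(F)(F)F)c1`: 1900 nM
- Compound 3, `O=S(=O)(NCCCNCc1ccc(Cl)c(Cl)c1)c1cc(C(F)(F)F)cc(C(F)(F)F)c1`: 1800 nM

All three compounds share the same core and were tested in a functional assay on Capan-2 cells (Homo sapiens) for inhibition, read by MTT assay, with a stated time of 72 h; a lower number here means a stronger inhibitor of growth, a higher number a weaker inhibitor of growth. Among the three numbers, compound 3 gives the lowest; its nearest neighbour is compound 2, which sits within the scatter of it, while compound 1 is the furthest away, with a gap that lies well beyond the scatter. Compound 4, `O=S(=O)(NCCCNCc1ccc(C(F)(F)F)cc1)c1cc(C(F)(F)F)cc(C(F)(F)F)c1`, is the next compound in this series. It differs from compound 3 in one place: 4-(trifluoromethyl)phenyl in place of 3,4-dichlorophenyl on a saturated chain carbon bound to an amine nitrogen.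

Among the compounds with values here, only one measured step touches this part of the molecule, a 1.1-fold lower number from compound 2 to compound 3 (0.02 log units; within the scatter). That step changed both the benzyl group and the chain at once and stayed within the scatter, so it gives no sign that a swap of one substituted benzyl ring for another moves the number much. Within the data shown here, there is no measured step in which only the ring substituents change. On that basis the step from compound 3 to compound 4 is expected to be small, a 1.4-fold higher number from compound 3 to compound 4 (0.14 log units; within the scatter), with no clear direction beyond the scatter. The estimate for compound 4 in this assay is therefore 2500 nM, expected to fall between 900 nM and 7000 nM.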

Compound 4, concentration for 50% growth inhibition: 2000 nM
The estimate for compound 4 lay 1.3-fold (0.10 log units) above the measured number; measured number inside the range.
By their numbers in this assay, from the lowest: compounds 3, 2 and 4 (each within the scatter of the next); then compound 1.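

In this assay the swap of 3,4-dichlorophenyl for 4-(trifluoromethyl)phenyl gives a 1.1-fold higher number from compound 3 to compound 4 (0.05 log units; within the scatter) and so leaves the two compounds indistinguishable. This is the first step shown in which the chain stays fixed and only the ring substituents differ, which makes it a cleaner reading of this position than the earlier step, where the benzyl group and the chain differed together. Here, a ring with 2 chlorine atoms and a ring with a trifluoromethyl group, holding 8 and 10 heavy atoms, give numbers that cannot be separated, although no evidence is available to explain why.

The compounds shown leave open whether this tolerance extends to a benzyl ring with no substituent at all, or to one carrying a carboxylic acid or an amine instead of halogen-containing groups. They also leave open whether the 4-(trifluoromethyl)benzyl group would give a similar number on a longer chain, where only the chain length differs from compound 4.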